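Methoxy Substitution in Two Bromoacrylamide Chalcone Series

This account rests on a few compounds, and the source may have more. Where it says the series, first, only, none or still open, it means among the compounds named here.

Measured compounds:
compound 1, `C=C(Br)C(=O)Nc1ccc(/C=C/C(=O)c2ccccc2)cc1`: 5000 nM
compound 2, `C=C(Br)C(=O)Nc1ccc(/C=C/C(=O)c2cccc(OC)c2)cc1`: 2100 nM
compound 3, `C=C(Br)C(=O)Nc1ccc(C(=O)/C=C/c2ccccc2)cc1`: 880 nM

In a functional assay on L1210 cells (Mus musculus) for antiproliferative activity, with a stated time of 48 h (a lower number here means a stronger inhibitor, a higher number a weaker inhibitor), compound 1 gives 5000 nM, compound 2 gives 2100 nM and compound 3 gives 880 nM. Compound 3 has the same atoms as compound 1 joined differently; the difference between the two cores is not broken down here. From compound 1 to compound 2 the change was methoxy in place of hydrogen on an aromatic carbon, and it gave a 2.4-fold lower number from compound 1 to compound 2 (0.38 log units; beyond the scatter). Compound 4, `C=C(Br)C(=O)Nc1ccc(C(=O)/C=C/c2ccc(OC)cc2)cc1`, carries the same kind of change on the core of compound 3, namely (methoxy in place of hydrogen on an aromatic carbon). The place is not identical: in compound 2 the methoxy sits meta to a large group, in compound 4 para to a large group. Because a 2.4-fold lower number from compound 1 to compound 2 (0.38 log units; beyond the scatter), a step of comparable, modest size is expected here: a 2.0-fold lower number from compound 3 to compound 4 (0.29 log units; within the scatter). Compound 4 is therefore estimated at 450 nM, in this assay, with a likely range from 200 nM to 1100 nM.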

Compound 4, half-maximal inhibitory concentration: 900 nM
Compound 4: the middle estimate sits 2.0-fold (0.30 log units) below what was measured, and the stated range covers the measured number.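

In this assay, methoxy in place of hydrogen on an aromatic carbon gave a 1.0-fold higher number from compound 3 to compound 4 (0.01 log units; within the scatter), so on this core the change left the number where it stood. Set beside the step on the other core, this result cannot be told apart from it: the same change on two cores in this assay, a 2.4-fold lower number (0.38 log units; beyond the scatter) from compound 1 to compound 2 and a 1.0-fold higher number (0.01 log units; within the scatter) from compound 3 to compound 4, 2.4-fold (0.39 log units) apart, within the scatter of two such steps. This shows no firm difference between the two cores, but it does not show that the change carries over unchanged, as each core offers a single pair and the methoxy does not sit in the same place on both.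

The compounds shown leave open how methoxy compares across the two cores when it stands in the same place. They also leave open what a hydroxyl group, an amine or a fluorine atom would do on either core.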